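Chloro in Place of Methyl, Tried a Second Time

The source may report more compounds than this note shows. Statements on the series, on what has been measured and on what is new or still open speak of the compounds shown alone.

Compound 1 `COc1ccc2[nH]c(-c3ccccc3)c(C(c3c(-c4ccccc4)[nH]c4ccc(C)cc34)C3C(=O)NN=C3C)c2c1` gives 1800 nM.
Compound 2 `COc1ccc2[nH]c(-c3ccccc3)c(C(c3c(-c4ccccc4)[nH]c4ccc(Cl)cc34)C3C(=O)NN=C3C)c2c1` gives 1100 nM.
Compound 3 `CC1=NNC(=O)C1C(c1c[nH]c2ccccc12)c1c(-c2ccccc2)[nH]c2ccc(C)cc12` gives 1300 nM.

These numbers come from a functional assay on A549 cells (Homo sapiens) for cytotoxicity, read by MTT assay; on this read-out lower numbers stand for stronger inhibition and higher numbers for weaker inhibition. Between compound 1 and compound 2 a single change was made, (chloro in place of methyl on an aromatic carbon), and the step it made was a 1.6-fold lower number from compound 1 to compound 2 (0.21 log units; within the scatter). Compound 3 is built on a different core; the difference between the two cores is not broken down here. Compound 4 `CC1=NNC(=O)C1C(c1c[nH]c2ccccc12)c1c(-c2ccccc2)[nH]c2ccc(Cl)cc12` is compound 3 carrying the same change, (chloro in place of methyl on an aromatic carbon), at a place described in the same words, so it is the same change. Because that change gave a 1.6-fold lower number from compound 1 to compound 2 (0.21 log units; within the scatter) in the first pair, the expected step here is a 1.5-fold lower number from compound 3 to compound 4 (0.18 log units; within the scatter). The expected value for compound 4 in this assay is therefore 850 nM, estimated to fall between 400 nM and 1800 nM.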

Compound 4, half-maximal inhibitory concentration: 1600 nM
Compound 4: middle estimate off by 1.9-fold (0.27 log units), on the low side; the range from low to high includes it.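

Within this assay the swap of chloro for methyl made a 1.2-fold higher number from compound 3 to compound 4 (0.09 log units; within the scatter) and so stayed inside the usual scatter of repeated measurements. The two steps point in opposite directions on paper, yet they do not truly differ: the same change on two cores in this assay, a 1.6-fold lower number (0.21 log units; within the scatter) from compound 1 to compound 2 and a 1.2-fold higher number (0.09 log units; within the scatter) from compound 3 to compound 4, 2.0-fold (0.30 log units) apart, within the scatter of two such steps. This shows that the change behaves alike on these two cores as far as the assay can tell, but since neither step stands clear of the scatter, it does not show that the swap has any real effect on either core.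

The compounds shown leave open what an amine, a carboxylic acid or a longer chain would do at this place. They also leave open whether any core beyond these two would respond in the same way.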